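From compound 3 to compound 4: a swapped chain group

The compounds below may be only part of what the source reports. "The series", "measured", "known", "first", "only" and "open" are said of these compounds alone.

In an in vitro ADME assay on microsomes from liver (Homo sapiens) for metabolic stability, tested at 5 uM (a higher number here means that the compound lasts longer, a lower number that the compound disappears faster), compound 3 `CS(=O)(=O)Nc1ccc2c(c1)S(=O)(=O)N=C(c1c(O)c(-c3cccs3)nn(CC3(C(F)(F)F)CC3)c1=O)N2` gives > 1 h, which is a limit and not a number. Compound 1 `CS(=O)(=O)Nc1ccc2c(c1)S(=O)(=O)N=C(c1c(O)c(-c3cccs3)nn(CCC3CC3)c1=O)N2` gives > 1 h, again a limit. Compound 2 `CC(C)(C)Cn1nc(-c2cccs2)c(O)c(C2=NS(=O)(=O)c3cc(NS(C)(=O)=O)ccc3N2)c1=O` gives > 1 h, also a limit. Compound 4 `CS(=O)(=O)Nc1ccc2c(c1)S(=O)(=O)N=C(c1c(O)c(-c3cccs3)nn(CCC3CCCC3)c1=O)N2` differs from compound 3 on a saturated chain carbon bound to an aromatic nitrogen: cyclopentylmethyl in place of 1-(trifluoromethyl)cyclopropyl on a saturated chain carbon bound to an aromatic nitrogen. Three measured steps change this same group: a step that the two limits leave unreadable from compound 1 to compound 2, a step that the two limits leave unreadable from compound 1 to compound 3 and a step that the two limits leave unreadable from compound 2 to compound 3. None has a readable size because of the limit of > 1 h in this assay, at which 3 of the 3 values shown sit. They point in no direction, so no step beyond the scatter is expected in this assay. The expected step is a step that the limit leaves unreadable from compound 3 to compound 4. Compound 4 is estimated at 1.5 h, with an expected range from 0.7 h to 3 h.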

Compound 4, half-life: > 1 h
Compound 4 ended at the assay's limit; the forecaster's own chance of this, stated with the estimate: 70%; the middle value is on the limit's open side.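

Compound 1, compound 2, compound 3 and compound 4 all sit at a limit and not at a number in this assay, so no step among them can be read: the limit of > 1 h in this assay, at which 4 of the 4 values shown sit.

As far as these compounds go, how far these four compounds differ in this assay, and whether the swapped chain groups change the half-life at all, stays open.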